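Isopropylamino in place of benzylamino on a weak starting point

The source may report more compounds than this note shows. Statements on the series, on what has been measured and on what is new or still open speak of the compounds shown alone.

Measured compounds:
Compound 1 `COc1ccc(-c2cnc3nc(N)nc(NCc4ccccc4)c3n2)cc1OC`: 13000 nM
Compound 2 `CC(C)Oc1nc(N)nc2ncc(-c3ccc(F)c(F)c3)nc12`: 10000 nM
Compound 3 `COc1ccc(-c2cnc3nc(N)nc(N4CCN(C(=O)COc5ccccc5)CC4)c3n2)cc1OC`: 4 nM

In a functional assay on cells (T-cell, Homo sapiens) for inhibition (on this read-out higher numbers stand for weaker inhibition and lower numbers for stronger inhibition), compound 1 gives 13000 nM, the highest of the three numbers and so the weakest inhibition shown. Compound 2 sits close to it, within the scatter, so no order between these two can be claimed. Compound 3, with a different group on the shared core, lies far beyond the scatter at the strong end.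

Compound 4 `COc1ccc(-c2cnc3nc(N)nc(NC(C)C)c3n2)cc1OC` is not yet measured. It differs from compound 1 by isopropyl in place of benzyl on a nitrogen on an aromatic ring. Within the data shown here, no measured pair shows this kind of exchange, so the expected step from compound 1 to compound 4 is estimated as small, a 1.2-fold higher number from compound 1 to compound 4 (0.06 log units; within the scatter), with no direction beyond the scatter. For compound 4 the estimate in this assay is 15000 nM, between 4000 nM and 50000 nM.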

Compound 4, half-maximal inhibitory concentration: 600 nM
For compound 4 the middle estimate is 25-fold (1.40 log units) above the measured one; the whole stated range lies above it.
By their numbers in this assay, from the lowest: compound 3; then compound 4; then compounds 2 and 1 (each within the scatter of the next).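

The benzylamino group is not needed at this position: in this assay, isopropylamino, which has no ring, gives a 22-fold lower number from compound 1 to compound 4 (1.34 log units; beyond the scatter), a large step. Among these compounds, no earlier pair differed in one place, so only this step shows how strongly the read-out depends on the group on this nitrogen. Nothing in the available data explains the size of this step.

From the compounds shown here alone, it remains open how methyl or cyclopropyl on this nitrogen would compare with isopropyl. Going by these compounds, it also remains open whether a longer chain, such as n-butyl, would keep this gain.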